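A few compounds are considered here, and "the series" means these few. Any claim that something is new, unique, unknown or untested is made for them only; others in the source may bear on it.

The study concerns a set of compounds sharing one core, each measured in an assay on cells with melanin-concentrating hormone receptor 1 (Homo sapiens) as the target, read by radioligand binding; a lower number here means a stronger inhibitor, a higher number a weaker inhibitor. Compound 1 `CCC(C)COc1cccc2ccc(N)nc12` gives 36 nM, and compound 3 `Nc1ccc2cccc(OCC3CC4CCC3C4)c2n1` gives 137 nM. Compound 2 `CCOCCOc1cccc2ccc(N)nc12` reaches only the limit of the measurement and gives > 2000 nM. Compound 2 thus stands at the weak end of the values shown, sitting at the limit of > 2000 nM in this assay, at which 1 of the 3 values shown sits. Going by the values given here, the one measured step that bears on the next change is an at least 55-fold higher number from compound 1 to compound 2 (1.74 log units; beyond the scatter), in which an ethoxy-containing chain replaced a plain alkyl chain. Compound 4 `CCCCCOc1cccc2ccc(N)nc12` differs from compound 2 by propyl in place of ethoxy on a saturated chain carbon, two bonds along the chain from an oxygen on an aromatic ring, restoring a plain alkyl chain. Because the step of an at least 55-fold higher number from compound 1 to compound 2 (1.74 log units; beyond the scatter) is large, a large fall in the number is expected, an at least 33-fold lower number from compound 2 to compound 4 (1.52 log units; beyond the scatter). Compound 4 is estimated at 60 nM, with a range of 15 nM to 250 nM.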

Compound 4, half-maximal inhibitory concentration: 580 nM
Beside the measured number, compound 4's estimate is 9.7-fold (0.99 log units) below it; the whole stated range lies below it.
By their numbers in this assay, from the lowest: compound 1; then compound 3; then compound 4. At a limit, above all of these: compound 2.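

Propyl in place of ethoxy at this position gives an at least 3.4-fold lower number from compound 2 to compound 4 (0.53 log units; beyond the scatter), so a plain chain alone does not return the strength of compound 1. Butyl in place of sec-butyl, on the saturated chain carbon bound to an oxygen on an aromatic ring, gives a 16-fold higher number from compound 1 to compound 4 (1.21 log units; beyond the scatter), which shows that the shape of an all-carbon chain matters here as well. Compound 2 stands only at a limit: the limit of > 2000 nM in this assay, at which 1 of the 4 values shown sits.

The compounds shown leave open whether a longer chain or a chain carrying an amine would move the number further. They also leave open whether other branched chains would match compound 1.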